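Halogen swap on the aryl ketone of compound 1

This account rests on a few compounds, and the source may have more. Where it says the series, first, only, none or still open, it means among the compounds named here.

Measured in a functional assay on MDA-MB-468 cells (Homo sapiens) for inhibition, read by sulforhodamine B assay, with a stated time of 48 h; on this read-out lower numbers stand for stronger inhibition of growth and higher numbers for weaker inhibition of growth:
compound 1, `COc1cc(-c2cc(/C=C/C(=O)c3ccc(Cl)c(Cl)c3)[nH]n2)cc(OC)c1OC`, gives 7220 nM
compound 2, `COc1ccc(-c2cc(/C=C/C(=O)c3ccc(N)cc3)[nH]n2)cc1OC`, gives 3480 nM
compound 3, `COc1cc(C(=O)/C=C/c2cc(-c3cc(OC)c(OC)c(OC)c3)n[nH]2)cc(OC)c1OC`, gives 2480 nM

Compound 1 stands at the highest number of the three. Compound 2 lies beyond the usual scatter below it, and compound 3 further still, so on these three numbers compound 1 is the weakest inhibitor of growth in this assay. For the measured compounds named here, compound 2 and compound 3 are not separated from each other beyond the scatter, and no pair among the measured compounds differs in a single place, so no measured step is available.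

Compound 4, `COc1cc(-c2cc(/C=C/C(=O)c3ccc(F)c(F)c3)[nH]n2)cc(OC)c1OC`, has not yet been measured in this assay. It differs from compound 1 in one place: 3,4-difluorophenyl in place of 3,4-dichlorophenyl on a carbonyl carbon. Going by the values given here, nothing among the measured compounds sets one halogen against another on this ring, so the size and direction of the change cannot be read from the data. The step from compound 1 to compound 4 is expected to be small, a 1.1-fold higher number from compound 1 to compound 4 (0.04 log units; within the scatter), within the usual scatter. Compound 4 is accordingly estimated at 8000 nM in this assay, with a range from 3000 nM to 20000 nM, a result to be checked once the measurement is in hand.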

Compound 4, concentration for total growth inhibition: 9470 nM
For compound 4 the middle estimate is 1.2-fold (0.07 log units) below the measured one; the range from low to high includes it.
By their numbers in this assay, from the lowest: compounds 3 and 2 (each within the scatter of the next); then compounds 1 and 4 (each within the scatter of the next).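

In this assay the step is a 1.3-fold higher number from compound 1 to compound 4 (0.12 log units; within the scatter) and is the only direct comparison of two halogens on this ring among the compounds shown. It gives no separation: at this place, on a carbonyl carbon whose other neighbour is the double-bonded chain carbon, 3,4-difluorophenyl and 3,4-dichlorophenyl cannot be told apart on this read-out. No measured property of these groups is available to bear on this result.

On these data alone, the series therefore gives one comparison at this place, and only between two dihalogenated rings, so it remains open whether a bromine atom, a trifluoromethyl group, a nitrile or a plain phenyl ring would also leave the number within the scatter. Compound 2 and compound 3 differ from compound 1 in more than one place, so they cannot show whether a change at this place alone, such as a carboxylic acid or an amine on the ring, would move the number beyond the scatter.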